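Sulfonyl substituent variation on a shared piperidine-linked core

A few compounds are considered here, and "the series" means these few. Any claim that something is new, unique, unknown or untested is made for them only; others in the source may bear on it.

Of the compounds shown here, three with the same core have been measured in a functional assay on HeLa cells (Homo sapiens) for antiproliferative activity, read by MTT assay, with a stated time of 48 h; on this read-out higher numbers stand for weaker inhibition and lower numbers for stronger inhibition. Compound 1 `COc1ccc(-c2cn3cc(C4=CCN(S(=O)(=O)CCc5ccccc5)CC4)ccc3n2)cc1OC` gives 8980 nM in this assay. Compound 2 `COc1ccc(-c2cn3cc(C4=CCN(C(=O)C5CCCCC5)CC4)ccc3n2)cc1OC` gives 8060 nM. Compound 3 `COc1ccc(-c2cn3cc(C4=CCN(S(=O)(=O)C5CCCC5)CC4)ccc3n2)cc1OC` gives 6470 nM. The three steps between them are a 1.1-fold lower number from compound 1 to compound 2 (0.05 log units; within the scatter), a 1.4-fold lower number from compound 1 to compound 3 (0.14 log units; within the scatter) and a 1.2-fold lower number from compound 2 to compound 3 (0.10 log units; within the scatter). Compound 3 holds the lowest of the three numbers, yet its steps to compound 2 and to compound 1 are both within the scatter, so no order among the three can be stated.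

Compound 4 `COc1ccc(-c2cn3cc(C4=CCN(S(=O)(=O)c5ccccc5)CC4)ccc3n2)cc1OC` is not yet measured. It differs from compound 3 by phenyl in place of cyclopentyl on a sulfonyl sulfur. For the measured compounds named here, the only earlier change at the same position is the step from compound 1 to compound 3, which stayed within the scatter; the exchanges of the whole group on the ring nitrogen, from compound 1 to compound 2 and from compound 2 to compound 3, also stayed within the scatter. Nothing among these steps points to a move beyond the scatter, so the step to compound 4 is expected to be a 1.0-fold higher number from compound 3 to compound 4 (0.00 log units; within the scatter). Compound 4 is therefore estimated at 6500 nM, with a range from 3000 nM to 14000 nM.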

Compound 4, half-maximal inhibitory concentration: 12600 nM
For compound 4 the middle estimate is 1.9-fold (0.29 log units) below the measured one; low and high end bracket the measured number.
By their numbers in this assay, from the lowest: compounds 3, 2, 1 and 4 (each within the scatter of the next).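

For the compounds shown here, compound 4 is the first with an aromatic ring directly on the sulfonyl sulfur, and in this assay the exchange of cyclopentyl for phenyl gives a 1.9-fold higher number from compound 3 to compound 4 (0.29 log units; within the scatter), the widest step recorded so far, though it does not clear the scatter. Removing the ethylene portion of phenethyl while keeping the aromatic ring gives a 1.4-fold higher number from compound 1 to compound 4 (0.15 log units; within the scatter), and exchanging the whole cyclohexylcarbonyl group for phenylsulfonyl gives a 1.6-fold higher number from compound 2 to compound 4 (0.19 log units; within the scatter), so neither a non-aromatic or aromatic ring on sulfur, nor a sulfonyl or carbonyl link, separates these four compounds on this read-out. No independent measurement is available to explain where any of these numbers falls.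

On these data alone, all four compounds therefore remain unresolved from one another, and it is open whether any group at this position can produce a step beyond the scatter. A phenyl ring carrying an amine or a carboxylic acid, a benzyl group on the sulfonyl sulfur, or a small open-chain group such as methyl in that place would test this more sharply than further exchanges among unsubstituted carbon rings.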